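Benzyl to 2-methoxyphenyl on the amino-quinone core

The compounds below may be only part of what the source reports. "The series", "measured", "known", "first", "only" and "open" are said of these compounds alone.

Measured so far:
compound 1, `O=C1C=C(NCc2ccccc2)C(=O)c2c1nc1n2[C@H]2OC[C@@H](O)[C@H]2OC1`: 2670 nM
compound 2, `O=C1C(N2CCC2)=CC(=O)c2c1nc1n2[C@H]2OC[C@@H](O)[C@H]2OC1`: > 16000 nM

Going by the values given here, in a functional assay on MGC-803 cells (Homo sapiens) for inhibition, read by sulforhodamine B assay (on this read-out lower numbers stand for stronger inhibition and higher numbers for weaker inhibition), compound 1 gives 2670 nM, the only numerical value shown. Compound 2 gives only a limit, > 16000 nM, so no number is known for it. Compound 3, `COc1ccccc1NC1=CC(=O)c2nc3n(c2C1=O)[C@H]1OC[C@@H](O)[C@H]1OC3`, has not yet been measured. It differs from compound 1 in one place: 2-methoxyphenyl in place of benzyl on an amine nitrogen. Among the compounds with values here, no measured pair carries this change, so the size of the step is unknown; the step from compound 1 to compound 3 is expected to be small, a 1.2-fold higher number from compound 1 to compound 3 (0.08 log units; within the scatter), within the scatter in either direction. Compound 3 is therefore estimated at 3200 nM, between 1000 nM and 12000 nM.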

Compound 3, half-maximal inhibitory concentration: 1630 nM
Compound 3: middle estimate off by 2.0-fold (0.29 log units), on the high side, within the range that was stated.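

In this assay, going by these compounds alone, putting 2-methoxyphenyl in place of benzyl on the amine nitrogen gives a 1.6-fold lower number from compound 1 to compound 3 (0.21 log units; within the scatter), the first one-place step that can be read at this position. The amine nitrogen thus carries either group with no difference that stands out from the scatter, so this single step shows no sensitivity to the change. Nothing measured here explains the step.

Going by these compounds, it remains open whether a plain phenyl or a phenethyl group on the same nitrogen would behave alike. The part played by the methoxy group also stays unresolved, since no compound shown separates it from the change from benzyl to an aryl group.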